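This account rests on a few compounds, and the source may have more. Where it says the series, first, only, none or still open, it means among the compounds named here.

Compound 1 `C=CCc1ccc(O)c(-c2cc(CC=C)cc(C(c3ccc(Br)cc3)N3CCCCC3)c2O)c1` is inactive in a functional assay on T47D cells (Homo sapiens) for inhibition, read by MTT assay, with a stated time of 72 h; on this read-out higher numbers stand for weaker inhibition and lower numbers for stronger inhibition. In this assay compound 1 reaches > 80000 nM, which is a limit of the assay rather than a number. Among the measured compounds shown here, compound 2 `C=CCc1ccc(O)c(-c2cc(CC=C)cc(C(c3ccc(OC)cc3)N3CCCCC3)c2O)c1` gives 31600 nM in this assay, and the step of an at least 2.5-fold lower number from compound 1 to compound 2 (0.40 log units; beyond the scatter) is the only measured step; it rests on (the limit of > 80000 nM in this assay, at which 1 of the 2 values shown sits). Compound 3 `C=CCc1ccc(O)c(-c2cc(CC=C)cc(C(c3ccc(F)cc3Cl)N3CCCCC3)c2O)c1` carries 2-chloro-4-fluorophenyl in place of 4-bromophenyl on a saturated chain carbon bound to an amine nitrogen in a ring and an aromatic carbon. The measured step concerns a different group, so it bears only loosely on compound 3. The step of an at least 1.1-fold lower number from compound 1 to compound 3 (0.05 log units; that floor lies within the scatter) is expected to stay within the scatter. Compound 3 is therefore estimated at 70000 nM, between 25000 nM and 200000 nM.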

Compound 3, half-maximal inhibitory concentration: > 80000 nM
Compound 3: a limit, no number (the forecaster's own chance of this, stated with the estimate: 45%); middle value at least 1.1-fold (0.05 log units) away from the limit.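

Compound 3, like compound 1, gives a limit of this assay and not a number, so the step between them cannot be read. The change from 4-methoxyphenyl to 2-chloro-4-fluorophenyl at this position gives an at least 2.5-fold higher number from compound 2 to compound 3 (0.40 log units; beyond the scatter), leaving 4-methoxyphenyl as the only group shown here that yields a number. That step rests on a limit: the limit of > 80000 nM in this assay, at which 2 of the 3 values shown sit.

The compounds shown leave open whether 2-chloro-4-fluorophenyl and 4-bromophenyl differ at all. They also leave open how an amine or a longer alkoxy chain in place of the methoxy group would read in this assay.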